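A few compounds are considered here, and "the series" means these few. Any claim that something is new, unique, unknown or untested is made for them only; others in the source may bear on it.

Two compounds share one core and differ only in the group on the amide carbonyl. Compound 1 `CCOC(=O)c1sc(-c2cccc(NC(=O)c3ccc(C(C)(C)C)cc3)c2)nc1Nc1ccc(N2CCN(C)CC2)cc1` carries a 4-(tert-butyl)phenyl there, and in a functional assay on Raji cells (Homo sapiens) for antiproliferative activity, read by CCK-8 assay, with a stated time of 72 h, tested at 40 uM (a higher number here means more inhibition at the concentration tested (going by the name of the read-out), a lower number less inhibition), compound 1 gives 4.22%. For the measured compounds named here, compound 2 `CCOC(=O)c1sc(-c2cccc(NC(=O)c3ccccc3F)c2)nc1Nc1ccc(N2CCN(C)CC2)cc1` carries a 2-fluorophenyl instead, and in this assay compound 2 gives 89.8%, the higher of the two numbers measured so far; the change brought a number 85.6 percentage points higher from compound 1 to compound 2 (beyond the scatter).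

Compound 3 `CCOC(=O)c1sc(-c2cccc(NC(=O)c3ccc(F)c(Cl)c3)c2)nc1Nc1ccc(N2CCN(C)CC2)cc1` is not yet measured. It differs from compound 2 in this way: 3-chloro-4-fluorophenyl in place of 2-fluorophenyl on a carbonyl carbon. Going by the values given here, the one measured step concerns the same position, and it was large, but it swapped a bulky group for a small one, whereas here one small halogenated ring is exchanged for another. Among the compounds with values here, no measured pair isolates this exchange, so the expectation is loose. Compound 3 is expected to give about 50% in this assay, within 10% to 90%, which would mean an expected step of a number 39.8 percentage points lower from compound 2 to compound 3 (beyond the scatter).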

Compound 3, a percentage reported as inhibition, at one concentration (the size of the read-out at that concentration, not a potency): 20.7%
Compound 3: the middle estimate sits 29.3 percentage points above what was measured; measured number inside the range.
By their numbers in this assay, from the lowest: compound 1; then compound 3; then compound 2.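

In this assay the exchange of one small halogenated ring for another gives a number 69.1 percentage points lower from compound 2 to compound 3 (beyond the scatter), so large changes at this position on the carbonyl carbon are not tied to the 4-(tert-butyl)phenyl group alone. Set against that group, 3-chloro-4-fluorophenyl brings only a number 16.5 percentage points higher from compound 1 to compound 3 (beyond the scatter), so most of what 2-fluorophenyl gained is gone, even though both rings carry fluorine. No measurement shown here gives a reason for this drop.

The entering group differs from the leaving one both in its added chlorine and in where its fluorine stands, and these compounds cannot separate the two. As far as these compounds go, how a simple 4-fluorophenyl or 3-chlorophenyl ring would behave remains open, as does the effect of an amine on the ring.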